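Working notes: from compound 2 to compound 3

A few compounds are considered here, and "the series" means these few. Any claim that something is new, unique, unknown or untested is made for them only; others in the source may bear on it.

Measured so far:
compound 1, `Cc1cc(OCc2ccccc2)c2nc(C)c(C)n2c1`, 45%
compound 2, `Cc1nc2c(OCc3ccccc3)cccn2c1/N=C/N(C)C`, 12%

Two compounds of the shared core carry a number in a functional assay on the whole organism with Canis familiaris (Canis lupus familiaris) as the target, at a dose of 2 mg/kg by the intravenous route; on this read-out lower numbers stand for a weaker effect and higher numbers for a stronger effect at the one dose given. Compound 1 gives 45% in this assay. Compound 2 gives 12% and stands lowest of the two; the gap to compound 1 lies beyond the usual scatter. For the measured compounds named here, no step between compounds differing in a single place has been measured, so the two numbers show only that the pair differ and not what any one change does.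

Compound 3, `Cc1nc2c(OCc3ccccc3)cccn2c1N(C)C`, has not been measured in this assay. It differs from compound 2 as follows:
a group of 3 heavy atoms (2 carbon, 1 nitrogen; no ring) in place of a group of 5 heavy atoms (3 carbon, 2 nitrogen; no ring), on an aromatic carbon

There is no measured change of this kind to lean on. Given that compound 2 sits at 12%, the expectation for this assay is a step of moderate size upward, though a step that stays within the scatter cannot be excluded. The step from compound 2 to compound 3 is expected to be a number 13 percentage points higher from compound 2 to compound 3 (beyond the scatter). Compound 3 is estimated at 25%, with a range from 5% to 55%.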

Compound 3, a percentage reported as inhibition, in the whole organism at one dose (the size of the read-out at that dose, not a potency): 85%
Beside the measured number, compound 3's estimate is 60 percentage points below it; measured number outside the range, above it.
By their numbers in this assay, from the lowest: compound 2; then compound 1; then compound 3.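

For the compounds shown here, replacing the group of 5 heavy atoms with dimethylamino, on the aromatic carbon next to the ring nitrogen, gives a number 73 percentage points higher from compound 2 to compound 3 (beyond the scatter), the first single-place step in this assay, and a large one. This position is therefore far from indifferent to what it carries, even though the leaving and entering groups have the same hydrogen-bond donor and acceptor counts and neither has a net charge; those counts do not separate the two groups, whereas their heavy-atom counts and the double bond outside aromatic rings, which leaves with the larger group, do. No measurement at hand bears on why this exchange has such an effect.

The compounds shown leave open whether the gain belongs to dimethylamino itself or would extend to other nitrogen groups at this place, such as a primary amine, diethylamino or a pyrrolidine ring. Also open is whether the step would carry over with the benzyloxy group replaced, for instance by a simple methoxy group, since every compound shown keeps the benzyloxy group.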